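A few compounds are considered here, and "the series" means these few. Any claim that something is new, unique, unknown or untested is made for them only; others in the source may bear on it.

The compounds measured in a functional assay on HeLa cells (Homo sapiens) for cytotoxicity, read by neutral red uptake, with a stated time of 3 days; a higher number here means a weaker inhibitor, a lower number a stronger inhibitor:

compound 1 `Nc1ccc(-c2cc(=O)c3c(N)c(F)c(N)c(F)c3o2)cc1F`: 19000 nM
compound 2 `CCCCCC(=O)OCc1c(F)c(N)c2c(=O)cc(-c3ccc(N)c(F)c3)oc2c1F`: 34000 nM
compound 3 `CCCCCCCCCCCCCCCCCC(=O)OCc1c(F)c(N)c2c(=O)cc(-c3ccc(N)c(F)c3)oc2c1F`: a limit of the assay, > 100000 nM

Compound 1 holds the lowest of the two plain numbers, and compound 2 is nearest to it, with a 1.8-fold higher number from compound 1 to compound 2 (0.25 log units; within the scatter); no order between them is claimed. Compound 3 is described by the limit of > 100000 nM in this assay, at which 1 of the 3 values shown sits.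

Compound 4 `CCCCCCOCc1c(F)c(N)c2c(=O)cc(-c3ccc(N)c(F)c3)oc2c1F` is not yet measured. ((hexyloxy)methyl in place of amino on an aromatic carbon). The step from compound 1 to compound 2 exchanged amino at the same place for a group of comparable length and is the closest guide, while an at least 2.9-fold higher number from compound 2 to compound 3 (0.46 log units; beyond the scatter) shows that a much longer chain pushed the number up. The expected step is a 1.6-fold higher number from compound 1 to compound 4 (0.20 log units; within the scatter). Compound 4 is thus estimated at 30000 nM, between 12000 nM and 80000 nM.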

Compound 4, half-maximal inhibitory concentration: > 100000 nM
Compound 4 gave a limit, no number; the forecaster's own chance of this, stated with the estimate: 10%; at least 3.3-fold (0.52 log units) between middle value and limit.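

Placing (hexyloxy)methyl instead of amino on this aromatic carbon gives an at least 5.2-fold higher number from compound 1 to compound 4 (0.72 log units; beyond the scatter), whereas the ester in compound 2 stayed within the scatter of compound 1. Exchanging pentylcarbonyl for hexyl on the oxygen gives an at least 2.9-fold higher number from compound 2 to compound 4 (0.46 log units; beyond the scatter), so at this position the carbonyl counts, and a chain as long as that of compound 3 is not needed to reach the limit. Compound 3 and compound 4 cannot be ordered against each other: the limit of > 100000 nM in this assay, at which 2 of the 4 values shown sit.

As far as these compounds go, whether a hydroxymethyl or a methoxymethyl group at this position would stay near compound 1 remains open.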